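The source may hold more compounds than are shown below. What is called first, only, known or untested is meant among the compounds shown, and "the series" means these compounds.

In an ADME assay on Raji cells (Homo sapiens) for cytotoxicity, read by CellTiter-Glo, with a stated time of 72 h (a higher number here means that more compound is needed for the effect, a lower number that less compound is needed), compound 1 (`CC1=C2CC(C)(C)/C=C/C/C(C)=C\C3=C[C@H](C)C[C@]3(O2)C1=O`) gives 26000 nM, level with compound 2 (`C/C1=C/C2=C[C@H](C)C[C@@]23O[C@]2(CC(C)(C)C[C@@H]2[C@@]1(O)C(F)(F)F)[C@@H](C)C3=O`) at 26000 nM and compound 3 (`CC1=C2CC(C)(C)/C=C/[C@H](O)/C(C)=C\C3=C[C@H](C)C[C@]3(O2)C1=O`) at 26000 nM. Compound 4 (`CC(=O)O[C@@H]1/C=C/C(C)(C)CC2=C(C)C(=O)[C@]3(C[C@@H](C)C=C3/C=C\1C)O2`) keeps the core of compound 1 and has acetoxy in place of hydrogen on a saturated ring carbon. Going by the values given here, one measured step bears on this change, hydroxy in place of hydrogen on a saturated ring carbon, and it gave no change at the digits printed from compound 1 to compound 3 (within the scatter). Among the compounds with values here, no measured compound carries acetoxy itself, so this step is only a guide. No shift beyond the scatter is expected in this assay, and the expected step is no change at the digits printed from compound 1 to compound 4 (within the scatter). For compound 4 the estimated value is 26000 nM, with an expected range of 12000 nM to 40000 nM.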

Compound 4, half-maximal effective concentration: 26000 nM
The estimate for compound 4 equals the measured number at the digits printed; measured number inside the range.
By their numbers in this assay, from the lowest: compounds 1, 2, 3 and 4 (each within the scatter of the next).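

In this assay, placing acetoxy on this saturated ring carbon gives no change at the digits printed from compound 1 to compound 4 (within the scatter). Compound 3 had shown this only for hydroxy, whereas compound 4 extends it to a group of 4 heavy atoms with no hydrogen-bond donor, so both groups tried at this carbon leave the number where it stood. Nothing available explains why this position tolerates either group. Still open, on these data alone, is whether an amine or a carboxylic acid on this carbon would leave the number equally unmoved.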